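This account rests on a few compounds, and the source may have more. Where it says the series, first, only, none or still open, it means among the compounds named here.

Among the compounds with values here, compound 2 `CC(C)[C@H](NC(=O)C1(O)CC1)C(=O)N[C@@H](CC(=O)O)C(=O)CSCc1ccccc1` gives 12300 nM in an assay on isolated protein for inhibition of Caspase-8 (Homo sapiens); on this read-out lower numbers stand for stronger inhibition and higher numbers for weaker inhibition; the only other number, for compound 1 `CCC(O)(CC)C(=O)N[C@H](C(=O)N[C@@H](CC(=O)O)C(=O)CSCc1ccccc1)C(C)C` at 9580 nM, lies within the scatter of it, as the step of a 1.3-fold higher number from compound 1 to compound 2 (0.11 log units; within the scatter) shows. Compound 3 `CC(C)[C@H](NC(=O)C(O)(C(F)(F)F)C(F)(F)F)C(=O)N[C@@H](CC(=O)O)C(=O)CSCc1ccccc1` differs from compound 2 by 2,2,2-trifluoro-1-hydroxy-1-(trifluoromethyl)ethyl in place of 1-hydroxycyclopropyl on a carbonyl carbon. Within the data shown here, the one measured step at this position, from compound 1 to compound 2, stayed within the scatter, so for compound 3 no step beyond the scatter is expected in this assay in either direction. Compound 3 is estimated at 11000 nM, with a range of 4000 nM to 30000 nM, which means an expected step of a 1.1-fold lower number from compound 2 to compound 3 (0.05 log units; within the scatter).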

Compound 3, half-maximal inhibitory concentration: > 10000 nM
Compound 3 was reported as a limit (the forecaster's own chance of this, stated with the estimate: 15%); the middle value does not contradict the limit.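

In this assay the result for compound 3 is a limit and not a number: the limit of > 10000 nM in this assay, at which 1 of the 3 values shown sits. The step from compound 2 cannot be read, and the other comparison gives only a floor, an at least 1.0-fold higher number from compound 1 to compound 3 (0.01 log units; that floor lies within the scatter). No step beyond the scatter has therefore been read at this position, now including the open-chain 2,2,2-trifluoro-1-hydroxy-1-(trifluoromethyl)ethyl group.

As far as these compounds go, how far compound 3 actually lies from compound 1 and compound 2 stays open. So does how a group carrying an amine or a carboxylic acid on this carbonyl carbon would read.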